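A few compounds are considered here, and "the series" means these few. Any claim that something is new, unique, unknown or untested is made for them only; others in the source may bear on it.

Compound 1, `CNC(=O)c1nc(-c2cccs2)[nH]c(=O)c1O`, is the weaker-sounding anchor of this small set: in an assay on isolated protein for inhibition of deoxyribonuclease-1 (Homo sapiens) (on this read-out lower numbers stand for stronger inhibition and higher numbers for weaker inhibition), compound 1 gives 67600 nM. Compound 2, `CCCNC(=O)c1nc(-c2cccs2)[nH]c(=O)c1O`, reaches only a limit of this assay, > 100000 nM, so its true number is not known. Within the data shown here, the one measured step, an at least 1.4-fold higher number from compound 1 to compound 2 (0.17 log units; that floor lies within the scatter), rests on that limit, which is the limit of > 100000 nM in this assay, at which 1 of the 2 values shown sits, and so its size is only a floor.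

Compound 3, `O=C(NCCO)c1nc(-c2cccs2)[nH]c(=O)c1O`, has not been measured. It differs from compound 2 by hydroxy in place of methyl on a saturated chain carbon, two bonds along the chain from an amide-type nitrogen. Among the measured compounds shown here, no measured step exchanges a methyl for a hydroxy, so none bears directly on this change; the one known step shows only that lengthening the chain on compound 2 did not sharpen inhibition. For compound 3 a step of a number no higher from compound 2 to compound 3 (the limit leaves the size open) is therefore expected, that is no change beyond the scatter. Compound 3 is estimated at 100000 nM, between 30000 nM and 300000 nM, with a real chance that only a limit is reported.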

Compound 3, half-maximal inhibitory concentration: > 100000 nM
Compound 3 gave a limit, no number; the forecaster's own chance of this, stated with the estimate: 55%; the middle value lies on the limit itself.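

Putting hydroxy in place of methyl on the chain, which turns propyl into 2-hydroxyethyl, does not bring a readable number into view: compound 3 gives only a limit in this assay, as compound 2 does, and the step between these two compounds cannot be read. Among these compounds, the one readable comparison is an at least 1.4-fold higher number from compound 1 to compound 3 (0.17 log units; that floor lies within the scatter), a floor that shows no loss of inhibition beyond the scatter. What is new is that a chain carrying hydroxy ends at the same limit as the propyl chain, so only compound 1 still has a number: the limit of > 100000 nM in this assay, at which 2 of the 3 values shown sit.

As far as these compounds go, how far compound 2 and compound 3 lie past that limit stays unknown, as does whether either truly differs from compound 1. Also open, from the compounds shown here alone, is whether an amine or a carboxylic acid in place of that hydroxy would give a readable number.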